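Trimming a Side Chain While Watching Cell Toxicity

A few compounds are considered here, and "the series" means these few. Any claim that something is new, unique, unknown or untested is made for them only; others in the source may bear on it.

Three compounds sharing one core and a side chain that carries a triple bond have been tested in a functional assay on HEL cells (Homo sapiens) for cytotoxicity; on this read-out higher numbers stand for lower toxicity in this test and lower numbers for higher toxicity in this test. Compound 1 `CCCCC#Cc1cc2cn([C@@H]3O[C@H](CO)[C@@H](O)[C@H]3O)c(=O)nc2o1` reaches only a limit of the assay, > 144000 nM. Compound 2 `CCCCCCCCC#Cc1cc2cn([C@@H]3O[C@H](CO)[C@@H](O)[C@@H]3O)c(=O)nc2o1` likewise gives only a limit, > 124000 nM. For the measured compounds named here, compound 3 `CCCCCCCCCCC#Cc1cc2cn([C@@H]3O[C@H](CO)[C@@H](O)[C@@H]3O)c(=O)nc2o1` is the one compound with a number, 116000 nM. Going by the values given here, the single measured step, an at least 1.0-fold lower number from compound 2 to compound 3 (0.02 log units; that floor lies within the scatter), lies within the scatter, so lengthening the chain changes nothing visible. Compound 2 thus stands at a limit, and the other two values sit at a limit or close to it; none of the three shows toxicity within the tested range.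

Compound 4 `CCCCCCC#Cc1cc2cn([C@@H]3O[C@H](CO)[C@@H](O)[C@@H]3O)c(=O)nc2o1` is compound 2 with a shorter chain: hydrogen in place of ethyl on a saturated chain carbon, six bonds along the chain from a triple-bonded carbon. The step from compound 2 to compound 3 went the other way along the chain and stayed within the scatter. Compound 1, with a still shorter chain, sits at the limit of > 144000 nM in this assay, at which 1 of the 3 values shown sits. No change beyond the scatter is therefore expected in this assay. The step that the limit leaves unreadable from compound 2 to compound 4 is estimated to stay within the scatter. Compound 4 is expected to give 140000 nM, within 100000 nM to 200000 nM, most likely again only as a limit.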

Compound 4, half-maximal cytotoxic concentration: > 53000 nM
Compound 4: only a limit was reported (the forecaster's own chance of this, stated with the estimate: 70%); the middle value does not contradict the limit.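

Compound 4 gives only a limit, > 53000 nM. Its steps from compound 2 and from compound 3 therefore cannot be read. The compounds shown leave open whether the shorter chain of compound 4 changes the result in this assay at all.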